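Chain lengthening from compound 3 to compound 4

The source may hold more compounds than are shown below. What is called first, only, known or untested is meant among the compounds shown, and "the series" means these compounds.

In a functional assay on HCT-116 cells (Homo sapiens) for antiproliferative activity, read by MTT assay, with a stated time of 48 h (a higher number here means a weaker inhibitor, a lower number a stronger inhibitor), compound 1 (`CC(CCO)n1cnc2c(Cl)ncnc21`) gives > 50000 nM as a limit. Compound 2 (`CCC(CCO)n1cnc2c(Cl)ncnc21`) gives > 50000 nM as a limit. Compound 3 (`CCCCC(CCO)n1cnc2c(Cl)ncnc21`) gives > 50000 nM as a limit and so has no number of its own. Among the measured compounds shown here, the series so far rests on the limit of > 50000 nM in this assay, at which 3 of the 3 values shown sit, and on no readable value.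

The change to compound 4 (`CCCCCC(CCO)n1cnc2c(Cl)ncnc21`) is methyl in place of hydrogen on a saturated chain carbon, five bonds along the chain from an aromatic nitrogen on the chain of compound 3. Cut one bond further out, the same difference reads propyl to butyl.

The steps bearing on it are a step that the two limits leave unreadable from compound 1 to compound 2 and a step that the two limits leave unreadable from compound 1 to compound 3 together with a step that the two limits leave unreadable from compound 2 to compound 3 as the closest. None of them has a size, so none gives a size to carry over, and lengthening the chain has not yet produced a number in this assay in any of these compounds.

The expected step is a number no higher from compound 3 to compound 4 (the limit leaves the size open) with no direction to be read from the data. For compound 4 the estimate is 50000 nM as an expected value, with an estimated range from 25000 nM to 100000 nM and a further limit the likely report.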

Compound 4, half-maximal inhibitory concentration: > 50000 nM
Compound 4 ended at the assay's limit; the forecaster's own chance of this, stated with the estimate: 85%; the middle value sits exactly at the limit.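

In this assay compound 4 gives > 50000 nM, a limit and not a number. No new step can be read from compound 4 to compound 1, compound 2 or compound 3. The compounds shown leave open whether any chain on the shared core reaches a readable value in this assay.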